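A few compounds are considered here, and "the series" means these few. Any claim that something is new, unique, unknown or untested is made for them only; others in the source may bear on it.

Measured compounds:
- Compound 1 `CCOC(=O)c1ccc(Nc2ccnc(SCC(=O)c3ccc([N+](=O)[O-])cc3)n2)cc1` in a functional assay on K562 cells (Homo sapiens) for inhibition, read by sulforhodamine B assay, with a stated time of 48 h, tested at 10 uM; a lower number here means less inhibition of growth, a higher number more inhibition of growth at the concentration tested: 37%
- Compound 2 `CCOC(=O)c1ccc(Nc2ccnc(SCC(=O)c3ccc(C#N)cc3)n2)cc1`: 49%
- Compound 3 `CC(=O)c1cccc(Nc2ccnc(SCC(=O)c3ccc(-c4ccccc4)cc3)n2)c1`: 16%

Compound 3 gives the lowest of the three numbers; its gap to compound 1 and to compound 2 lies beyond the scatter, so it is the least inhibitory of the measured set. Compound 4 `COc1ccc(C(=O)CSc2nccc(Nc3cccc(C(C)=O)c3)n2)cc1` differs from compound 3 by a change on the aryl ketone side: methoxy in place of phenyl on an aromatic carbon. Among the measured compounds shown here, the only measured step with a change on that same ring is a number 12 percentage points higher from compound 1 to compound 2 (beyond the scatter), a swap of one small substituent for another; neither compound carries a phenyl or a methoxy there, so that step says little about the present change. For the measured compounds named here, with no close precedent, the step from compound 3 to compound 4 in this assay is expected to be small, a number 6 percentage points higher from compound 3 to compound 4 (within the scatter), with the direction uncertain. Compound 4 is therefore estimated at 22%, within a range of 5% to 42%.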

Compound 4, percent growth inhibition at one concentration: 37%
Compound 4: the middle estimate sits 15 percentage points below what was measured; the measured number falls inside the stated range.
By their numbers in this assay, from the lowest: compound 3; then compounds 1 and 4 (each within the scatter of the next); then compound 2.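

In this assay, methoxy in place of phenyl on the aromatic carbon para to a large group gives a number 21 percentage points higher from compound 3 to compound 4 (beyond the scatter). Among the compounds shown here, this is the first step at this position in which a whole six-membered aromatic ring leaves, and it shows that the number responds to that exchange and not only to a swap of one small substituent for another. The change removes a ring and heavy atoms and adds a hydrogen-bond acceptor all at once, and no measured property accounts for the step.

This single step cannot separate those features from one another. Still open, on these data alone, is how an ethoxy group, a dimethylamino group or a plain hydrogen at this place would read, and whether methoxy would give a similar step on the core carrying the ethyl ester.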